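The source may hold more compounds than are shown below. What is called first, only, known or untested is meant among the compounds shown, and "the series" means these compounds.

Of the compounds shown here, two sharing one core have been measured in a functional assay on HCT-116 cells (Homo sapiens) for inhibition, read by MTT assay, with a stated time of 72 h; on this read-out higher numbers stand for weaker inhibition and lower numbers for stronger inhibition. Compound 1 (`CNC(=O)CCCCCCCn1nc(-c2cnc3[nH]ccc3c2)c2c(N)ncnc21`), with a methylcarbamoyl group at its chain end, gives 6760 nM. Compound 2 (`Nc1ncnc2c1c(-c1cnc3[nH]ccc3c1)nn2CCCCCCCCC(=O)NO`), with a hydroxycarbamoyl group at its chain end, gives 5460 nM. These two numbers cannot be told apart, so compound 2 stands level with compound 1 in this assay.

Compound 3 (`Nc1ncnc2c1c(-c1cnc3[nH]ccc3c1)nn2CCCCC(=O)NO`) keeps the core and the hydroxycarbamoyl group on a shorter chain: hydroxycarbamoyl in place of 4-(hydroxycarbamoyl)butyl on a saturated chain carbon, four bonds along the chain from an aromatic nitrogen. In words, hydroxycarbamoyl takes the place of 4-(hydroxycarbamoyl)butyl on a saturated chain carbon, four bonds along the chain from an aromatic nitrogen. Among the compounds with values here, only one measured step bears on this change, a 1.2-fold lower number from compound 1 to compound 2 (0.09 log units; within the scatter), and it stays within the scatter. Within the data shown here, that step alters the chain end, and no measured pair shows a shortening of this size, so the data constrain the outcome only loosely. A small rise in the number is expected, with little support and with no change beyond the scatter also plausible. The expected shift is a 1.6-fold higher number from compound 2 to compound 3 (0.19 log units; within the scatter). For compound 3 the estimated value is 8500 nM, within an expected range from 2500 nM to 29000 nM.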

Compound 3, half-maximal inhibitory concentration: > 150000 nM
Compound 3 gave a limit, no number; the forecaster's own chance of this, stated with the estimate: 15%; middle value at least 17-fold (1.24 log units) away from the limit.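

In this assay compound 3 gives > 150000 nM, which is a limit of the assay and not a number: the limit of > 150000 nM in this assay, at which 1 of the 3 values shown sits.

Even read as a limit, the result shows that this position is sensitive to chain length: with the hydroxycarbamoyl end kept, the shorter chain gives an at least 27-fold higher number from compound 2 to compound 3 (1.43 log units; beyond the scatter). Set against the other long-chain compound, the picture is the same, with an at least 22-fold higher number from compound 1 to compound 3 (1.34 log units; beyond the scatter), whereas the earlier change at the chain end alone gave only a 1.2-fold lower number from compound 1 to compound 2 (0.09 log units; within the scatter), so among these three compounds the large change comes only with the shorter chain.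

The compounds shown leave open where between the two chain lengths the number begins to climb, and whether a longer chain would lower it further or raise it again. They also leave open whether a carboxylic acid or an amine at the chain end would behave like hydroxycarbamoyl and methylcarbamoyl on the long chain, and whether methylcarbamoyl on the short chain would show the same large change.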